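Adding a Methoxy Group to Compound 1

This account rests on a few compounds, and the source may have more. Where it says the series, first, only, none or still open, it means among the compounds named here.

Compound 1 `COc1ccc(Cl)cc1NC(=O)Cc1nn(CC(=O)O)c(=O)c2ccccc12`: > 1790 nM
Compound 2 `CCOc1cc2nn(Cc3nn(CC(=O)O)c(=O)c4ccccc34)cc2cc1Cl`: > 6640 nM
Compound 3 `O=C(O)Cn1nc(Cc2nc3cc(Cl)c(OC(F)(F)F)cc3[nH]2)c2ccccc2c1=O`: 31 nM

Of the compounds shown here, three have been tested in a functional assay on CHO cells for antagonist activity at sphingosine 1-phosphate receptor 2 (Homo sapiens), read by calcium flux; on this read-out higher numbers stand for weaker inhibition and lower numbers for stronger inhibition. For compound 1 the value > 1790 nM is a limit of this assay, not a number; this is the limit of > 1790 nM in this assay, at which 1 of the 3 values shown sits. For compound 2 the value > 6640 nM is likewise a limit, (the limit of > 6640 nM in this assay, at which 1 of the 3 values shown sits). Compound 3 gives 31 nM, a number. Compound 1 therefore stands at a limit, and of the values shown only compound 3 carries a number.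

Compound 4 `COc1cc(OC)c(NC(=O)Cc2nn(CC(=O)O)c(=O)c3ccccc23)cc1Cl` differs from compound 1 by methoxy in place of hydrogen on an aromatic carbon. Within the data shown here, no measured pair shows such a change, so the step from compound 1 to compound 4 is expected to stay within the scatter, a step that the limit leaves unreadable from compound 1 to compound 4. Compound 4 is estimated at 3000 nM, between 800 nM and 15000 nM, most likely reported as a limit again.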

Compound 4, half-maximal inhibitory concentration: 186 nM
Compound 4: middle estimate off by 16-fold (1.21 log units), on the high side; the whole stated range lies above it.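

Putting a methoxy group on this aromatic carbon, ortho to the chloro group and meta to the existing methoxy group, gives an at least 9.6-fold lower number from compound 1 to compound 4 (0.98 log units; beyond the scatter), so this position clearly affects the read-out. Among these compounds, compound 4 is the first of the compounds with the amide link to carry a number rather than a limit. Compound 1 stands only at a limit, so the step gives the smallest size the change can have: the limit of > 1790 nM in this assay, at which 1 of the 4 values shown sits.

The compounds shown leave open whether an ethoxy group, a fluoro group or an amine on this carbon would do the same. They also leave open whether the step depends on the neighbouring chloro group.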